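From 4-chlorophenyl to 3-fluorophenyl on a shared core

This account rests on a few compounds, and the source may have more. Where it says the series, first, only, none or still open, it means among the compounds named here.

Compound 1 `S=C(NCc1ccccc1)N/N=C/c1ccc2ccccc2n1`: 62800 nM
Compound 2 `Cc1ccc(NC(=S)N/N=C/c2ccc3ccccc3n2)cc1`: 86000 nM
Compound 3 `S=C(N/N=C/c1ccc2ccccc2n1)Nc1ccc(Cl)cc1`: > 100000 nM (a limit)

All three values come from a functional assay on HeLa cells (Homo sapiens) for antiproliferative activity, read by sulforhodamine B assay, with a stated time of 72 h; a lower number here means a stronger inhibitor, a higher number a weaker inhibitor. Compound 3 has no number there, only a limit, and stands at the limit of > 100000 nM in this assay, at which 1 of the 3 values shown sits. Compound 4 `Fc1cccc(NC(=S)N/N=C/c2ccc3ccccc3n2)c1` differs from it by 3-fluorophenyl in place of 4-chlorophenyl on an amide-type nitrogen, with 3-fluorophenyl in place of 4-chlorophenyl on an amide-type nitrogen. The measured steps that bear on this change are a 1.4-fold higher number from compound 1 to compound 2 (0.14 log units; within the scatter), an at least 1.5-fold higher number from compound 1 to compound 3 (0.20 log units; that floor lies within the scatter) and an at least 1.1-fold higher number from compound 2 to compound 3 (0.06 log units; that floor lies within the scatter). With compound 1, compound 2 and compound 3 this close, no change beyond the scatter is expected. The estimated step is an at least 1.3-fold lower number from compound 3 to compound 4 (0.12 log units; that floor lies within the scatter). For compound 4 the expected value is 75000 nM, with an estimated range of 35000 nM to 120000 nM.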

Compound 4, half-maximal inhibitory concentration: 70100 nM
For compound 4 the middle estimate is 1.1-fold (0.03 log units) above the measured one; the measured number falls inside the stated range.
By their numbers in this assay, from the lowest: compounds 1, 4 and 2 (each within the scatter of the next). At a limit, above all of these: compound 3.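

Compound 3 stands only at a limit in this assay: the limit of > 100000 nM in this assay, at which 1 of the 4 values shown sits. Against that limit, 3-fluorophenyl on the amide-type nitrogen gives an at least 1.4-fold lower number from compound 3 to compound 4 (0.15 log units; that floor lies within the scatter), so the size of this step stays open, while the fully measured comparisons give a 1.2-fold lower number from compound 2 to compound 4 (0.09 log units; within the scatter) and a 1.1-fold higher number from compound 1 to compound 4 (0.05 log units; within the scatter). Benzyl, 4-methylphenyl and 3-fluorophenyl on this nitrogen thus all lie within the scatter of one another. Going by these compounds, whether an amine, a carboxylic acid or a longer chain on the amide-type nitrogen would move the number beyond the scatter remains open.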